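From 4-Methylpiperazin-1-yl to Dimethylamino on the Amide

A few compounds are considered here, and "the series" means these few. Any claim that something is new, unique, unknown or untested is made for them only; others in the source may bear on it.

Compound 1 `CN1CCN(C(=O)/C=C/c2ccncc2-c2ccc3ccccc3c2)CC1` gives > 10000 nM in a functional assay on KB cells (Homo sapiens) for inhibition, read by sulforhodamine B assay, with a stated time of 72 h; a lower number here means a stronger inhibitor of growth, a higher number a weaker inhibitor of growth; this is a limit of the assay, not a number.
Compound 2 `CCOC(=O)/C=C/c1ccncc1-c1ccc2cc[nH]c2c1` gives 7860 nM in this assay.
Compound 3 `O=C(/C=C/c1ccncc1-c1ccc2ccccc2c1)N1CCOCC1` gives > 10000 nM in this assay, again a limit of the assay.

Compound 1 therefore stands at the limit of > 10000 nM in this assay, at which 2 of the 3 values shown sit, and where it truly lies is not known. Among the compounds with values here, the one measured step that touches it, a step that the two limits leave unreadable from compound 1 to compound 3, is unreadable for that reason. Within the data shown here, compound 2, built on a different core with an ester in place of the amide, is the only numbered value and sits close to that limit itself.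

Compound 4 `CN(C)C(=O)/C=C/c1ccncc1-c1ccc2ccccc2c1` differs from compound 1 by dimethylamino in place of 4-methylpiperazin-1-yl on a carbonyl carbon. Among the measured compounds shown here, no measured step shows what this change does. The expectation for compound 4 rests on compound 1 and compound 3 both sitting at the limit of > 10000 nM in this assay, at which 2 of the 3 values shown sit, so compound 4 is expected to give 15000 nM, within 4000 nM to 60000 nM. That estimate means an expected step that the limit leaves unreadable from compound 1 to compound 4, most likely reported once more as a limit rather than a number.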

Compound 4, concentration for 50% growth inhibition: 7760 nM
Compound 4: middle estimate off by 1.9-fold (0.29 log units), on the high side; the range from low to high includes it.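

With dimethylamino on the carbonyl carbon, compound 4 is the first of the amides shown to give a number rather than a limit in this assay. The change can now be read as an at least 1.2-fold lower number from compound 1 to compound 4 (0.11 log units; that floor lies within the scatter), and likewise as an at least 1.2-fold lower number from compound 3 to compound 4 (0.11 log units; that floor lies within the scatter). Each reading is only a floor and its true size stays unknown, because compound 1 and compound 3 each give a limit of the assay, not a number: the limit of > 10000 nM in this assay, at which 2 of the 4 values shown sit.

The compounds shown leave open how far compound 1 and compound 3 truly lie from compound 4, so it remains unclear whether this change matters at all. They also leave open what other groups on this carbonyl carbon would give, such as a simple amine bearing the amide hydrogen, a longer chain on the amide nitrogen, or a carboxylic acid in place of the amide.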